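Methoxy to methyl on the aryl ring, cyanosulfanyl core

The source may report more compounds than this note shows. Statements on the series, on what has been measured and on what is new or still open speak of the compounds shown alone.

Compound 1 `COc1ccc(-c2nc3sc(Cc4ccc(Cl)cc4)nn3c2Br)cc1` is the reference. In an ADME assay on CCRF-CEM cells (Homo sapiens) for cytotoxicity, with a stated time of 72 h (on this read-out lower numbers stand for stronger inhibition and higher numbers for weaker inhibition), compound 1 gives 58000 nM. Compound 2 `Cc1ccc(-c2nc3sc(Cc4ccc(Cl)cc4)nn3c2Br)cc1` carries methyl in place of methoxy on an aromatic carbon. For compound 2 the read-out in this assay is a limit, > 250000 nM, and the relevant boundary is the limit of > 250000 nM in this assay, at which 1 of the 3 values shown sits. The step of an at least 4.3-fold higher number from compound 1 to compound 2 (0.63 log units; beyond the scatter) therefore can only be bounded from one side. Compound 3 `COc1ccc(-c2nc3sc(Cc4ccc(Cl)cc4)nn3c2SC#N)cc1` differs from compound 1 in the core, (cyanosulfanyl in place of bromo on an aromatic carbon), and in this assay compound 3 gives 10000 nM; this step, a 5.8-fold lower number from compound 1 to compound 3 (0.76 log units; beyond the scatter), runs in the favourable direction, and compound 3 holds the lowest number among the two numbers measured.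

Compound 4 `Cc1ccc(-c2nc3sc(Cc4ccc(Cl)cc4)nn3c2SC#N)cc1` is not yet measured. It stands to compound 3 as compound 2 stands to compound 1: methyl in place of methoxy on an aromatic carbon. The place lines of the two changes read the same word for word, so the change is the same one, now made on the cyanosulfanyl core rather than on the bromo core.

The expectation for compound 4 in this assay rests on compound 1 and compound 2, where the change gave an at least 4.3-fold higher number from compound 1 to compound 2 (0.63 log units; beyond the scatter); a step of similar size, a 5.0-fold higher number from compound 3 to compound 4 (0.70 log units; beyond the scatter), is expected for compound 4. Compound 4 is thus estimated at 50000 nM, with a plausible range from 20000 nM to 200000 nM, and the chance of another limit rather than a number is not negligible given the outcome seen for compound 2.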

Compound 4, half-maximal inhibitory concentration: 22000 nM
Compound 4: middle estimate off by 2.3-fold (0.36 log units), on the high side, and the stated range covers the measured number.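

In this assay, the change from 4-methoxyphenyl to 4-methylphenyl on the cyanosulfanyl core gives a 2.2-fold higher number from compound 3 to compound 4 (0.34 log units; beyond the scatter), the same direction as on the bromo core: the same change on two cores in this assay, an at least 4.3-fold higher number (0.63 log units; beyond the scatter) from compound 1 to compound 2 and a 2.2-fold higher number (0.34 log units; beyond the scatter) from compound 3 to compound 4; the limit leaves it open whether they differ. Cyanosulfanyl in place of bromo, read on the 4-methylphenyl pair, gives an at least 11-fold lower number from compound 2 to compound 4 (1.05 log units; beyond the scatter), the same direction as on the 4-methoxyphenyl pair: the same change on two cores in this assay, a 5.8-fold lower number (0.76 log units; beyond the scatter) from compound 1 to compound 3 and an at least 11-fold lower number (1.05 log units; beyond the scatter) from compound 2 to compound 4; the limit leaves it open whether they differ. Compound 2 stands at > 250000 nM, which is a limit and not a number; across these two pairs the direction of each change carries from one core to the other, but whether its size carries over stays unsettled, and two pairs show no rule for the wider series.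

The compounds shown leave open how a hydroxy group or an amine would read in place of methoxy on the aromatic ring, and how a nitrile or a methylsulfanyl group would read in place of cyanosulfanyl on the core. They also leave open whether the two changes would keep their direction with a longer chain or a carboxylic acid in place of the methyl or methoxy group.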